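Swapping 3-nitrophenyl for 4-methoxyphenyl on a shared core

The source may report more compounds than this note shows. Statements on the series, on what has been measured and on what is new or still open speak of the compounds shown alone.

Values in a functional assay on HeLa cells (Homo sapiens) for antiproliferative activity, read by MTT assay, with a stated time of 48 h (a lower number here means a stronger inhibitor, a higher number a weaker inhibitor), for three compounds:
- compound 1 `O=[N+]([O-])c1cccc(-c2nn(-c3ccccc3)cc2C(Nc2nc3ccccc3s2)c2c(O)ccc3ccccc23)c1` gives 8220 nM
- compound 2 `Cc1ccc(-c2nn(-c3ccccc3)cc2C(Nc2nc3cc(C)c(C)cc3s2)c2c(O)ccc3ccccc23)cc1` gives 17800 nM
- compound 3 `Cc1cccc(-c2nn(-c3ccccc3)cc2C(Nc2nc3ccccc3s2)c2c(O)ccc3ccccc23)c1` gives 7020 nM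

Compound 1 stands level with compound 3 and clearly lower than compound 2. Compound 4 `COc1ccc(-c2nn(-c3ccccc3)cc2C(Nc2nc3ccccc3s2)c2c(O)ccc3ccccc23)cc1` has 4-methoxyphenyl in place of 3-nitrophenyl on an aromatic carbon of the core 4-methoxyphenyl in place of 3-nitrophenyl on an aromatic carbon in its structure. The closest measured change, methyl in place of nitro, gave only a small step (a 1.2-fold lower number from compound 1 to compound 3 (0.07 log units; within the scatter)). Among the measured compounds shown here, compound 2 differs from compound 1 in more than one place, and no measured compound carries methoxy. No step beyond the scatter is therefore expected in this assay. The estimated change is a 1.0-fold lower number from compound 1 to compound 4 (0.01 log units; within the scatter) at most a small one. Compound 4 is expected near 8000 nM with an estimated range from 4000 nM to 16000 nM around it.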

Compound 4, half-maximal inhibitory concentration: 9340 nM
For compound 4 the middle estimate is 1.2-fold (0.07 log units) below the measured one, within the range that was stated.
By their numbers in this assay, from the lowest: compounds 3, 1, 4 and 2 (each within the scatter of the next, the first and the last beyond it).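

In this assay the shared core shows a 1.1-fold higher number from compound 1 to compound 4 (0.06 log units; within the scatter) and a 1.3-fold higher number from compound 3 to compound 4 (0.12 log units; within the scatter) when 4-methoxyphenyl sits on this aromatic carbon. So the earlier methyl-for-nitro step now has company: a whole-group swap, bringing methoxy and a 4-substituted phenyl, also stays within the scatter. Nothing available here explains this result. Still open, going by these compounds, is whether this place tolerates every group, since a phenyl carrying an amine or a carboxylic acid could give a clearly different number.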